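From Fluoro to Bromo at an Assay Limit

The source may hold more compounds than are shown below. What is called first, only, known or untested is meant among the compounds shown, and "the series" means these compounds.

Compound 1 `O=C(COc1ccc(C(=O)/C=C/c2ccc(F)cc2)cc1)N[C@H]1CCOC1=O`: > 64000 nM
Compound 2 `O=C(CNc1cccc(Cl)c1)N[C@H]1CCOC1=O`: > 64000 nM

In a functional assay on MGC-803 cells (Homo sapiens) for antiproliferative activity, read by MTT assay, with a stated time of 72 h (on this read-out lower numbers stand for stronger inhibition and higher numbers for weaker inhibition), compound 1 gives > 64000 nM, which is a limit of the assay and not a number. Compound 2 gives > 64000 nM, which is also a limit. Compound 1 therefore stands at the limit of > 64000 nM in this assay, at which 2 of the 2 values shown sit. Among the compounds with values here, no measured pair here shows how a single change moves the result, so the starting point is known only as a limit.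

Compound 3 `O=C(COc1ccc(C(=O)/C=C/c2ccc(Br)cc2)cc1)N[C@H]1CCOC1=O` keeps the rest of compound 1 and makes one change: bromo in place of fluoro on an aromatic carbon. This atom sits para to a large group, so 4-fluorophenyl becomes 4-bromophenyl.

With so little to go on, only a modest expectation is reasonable. The step expected in this assay is small, estimated as an at least 1.0-fold lower number from compound 1 to compound 3 (0.02 log units; that floor lies within the scatter), and it may stay within the usual scatter. The assay may well report only a limit again. For compound 3 the estimated value is 60000 nM, with an expected range of 20000 nM to 90000 nM.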

Compound 3, half-maximal inhibitory concentration: 51000 nM
Compound 3: middle estimate off by 1.2-fold (0.07 log units), on the high side, and the stated range covers the measured number.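

Compound 3 gives the first readable number in this assay, whereas the earlier compounds offered only a limit: the limit of > 64000 nM in this assay, at which 2 of the 3 values shown sit.

The change from 4-fluorophenyl to 4-bromophenyl, made on an aromatic carbon, comes out as an at least 1.2-fold lower number from compound 1 to compound 3 (0.09 log units; that floor lies within the scatter). That figure is a floor and not a measured size: the value of compound 1 is a limit, so the true step may be larger, and all that can firmly be said is that this one swap of atoms leads from a limit to a number.

The compounds shown leave open how other groups on this same carbon would read in this assay, for instance chloro, a methoxy group or an amine, and so whether bromo is special here or just one of several workable choices. They also leave open whether a change elsewhere in the core of compound 3, such as a longer chain in place of the short link to the amide, would move the result by a step clearly beyond the usual scatter.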